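A few compounds are considered here, and "the series" means these few. Any claim that something is new, unique, unknown or untested is made for them only; others in the source may bear on it.

For the measured compounds named here, in a functional assay on A549 cells (Homo sapiens) for inhibition, read by MTT assay, with a stated time of 48 h (a higher number here means a weaker inhibitor, a lower number a stronger inhibitor), compound 2 `COc1ccc(N(C)c2nc(C)nc3ccccc23)cc1[Se]C` gives 11 nM, the lower of the two numbers so far, while compound 1 `COc1ccc(N(C)c2nc(C)nc3ccccc23)cc1C(=O)OCC[Se]C#N` gives 353 nM. Compound 3 `COc1ccc(N(C)c2nc(C)nc3ccccc23)cc1OCC[Se]C#N` has not been measured. It differs from compound 2 by a group of 6 heavy atoms (3 carbon, 1 nitrogen, 1 oxygen, 1 selenium; no ring) in place of a group of 2 heavy atoms (1 carbon, 1 selenium; no ring), on an aromatic carbon, ortho to a methoxy group. Going by the values given here, the one measured step bearing on this is a 32-fold lower number from compound 1 to compound 2 (1.51 log units; beyond the scatter), a large step, and the group lost there resembles the group entering here. The reverse direction, a higher number, is therefore expected, though the two larger groups are not identical and the size is uncertain. The expected change is a 7.3-fold higher number from compound 2 to compound 3 (0.86 log units; beyond the scatter). For compound 3 the estimate is 80 nM, within an expected range of 15 nM to 400 nM.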

Compound 3, half-maximal inhibitory concentration: 13 nM
The estimate for compound 3 lay 6.2-fold (0.79 log units) above the measured number; measured number outside the range, below it.
By their numbers in this assay, from the lowest: compounds 2 and 3 (each within the scatter of the next); then compound 1.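

In this assay, the step of a 1.2-fold higher number from compound 2 to compound 3 (0.07 log units; within the scatter) shows that this aromatic carbon tolerates the group of 6 heavy atoms, with its nitrile and selenium, as well as the far smaller group of 2 heavy atoms. The step of a 27-fold lower number from compound 1 to compound 3 (1.43 log units; beyond the scatter) shows that a long group here does not in itself go with a high number, since the large gap appears only with the group of 8 heavy atoms, which holds a carbonyl. Nothing available explains this difference. Whether the selenium or the nitrile is needed remains open, as a plain ethoxy group is not among these compounds. Also open, going by these compounds, is how an amine link or a longer chain at this carbon would behave.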